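A few compounds are considered here, and "the series" means these few. Any claim that something is new, unique, unknown or untested is made for them only; others in the source may bear on it.

In a functional assay on MCF7 cells (Homo sapiens) for inhibition, read by fluorescence, with a stated time of 72 h (a lower number here means a stronger inhibitor, a higher number a weaker inhibitor), compound 1 `CC(C)n1cnc2c(NC(=N)N)nc(NCCCO)nc21` gives 8800 nM and compound 2 `CC(C)[C@H](CO)Nc1nc(NC(=N)N)c2ncn(C(C)C)c2n1` gives 10500 nM, so compound 2 stands level with compound 1 within the scatter. Compound 3 `CC(C)n1cnc2c(NC(=N)N)nc(OC[C@H]3CCCN3)nc21` differs from compound 2 at one place: (pyrrolidin-2-yl)methoxy in place of (1-(hydroxymethyl)-2-methylpropyl)amino on an aromatic carbon, with (pyrrolidin-2-yl)methoxy in place of (1-(hydroxymethyl)-2-methylpropyl)amino on an aromatic carbon. Going by the values given here, the only measured step, a 1.2-fold higher number from compound 1 to compound 2 (0.08 log units; within the scatter), exchanged one amino side chain for another and stayed within the scatter. Among the compounds with values here, no measured compound carries the entering group, so the evidence is thin and no step beyond the scatter is expected in this assay. The expected change is a 1.3-fold lower number from compound 2 to compound 3 (0.12 log units; within the scatter). For compound 3 the estimate is 8000 nM, with an expected range of 2500 nM to 25000 nM.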

Compound 3, half-maximal inhibitory concentration: > 100000 nM
Compound 3 gave a limit, no number; the forecaster's own chance of this, stated with the estimate: 10%; at least 12-fold (1.09 log units) between middle value and limit.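

The aromatic carbon carrying these side chains is not indifferent to its substituent: a 1.2-fold higher number from compound 1 to compound 2 (0.08 log units; within the scatter), but replacing the amino chain with (pyrrolidin-2-yl)methoxy gives an at least 9.5-fold higher number from compound 2 to compound 3 (0.97 log units; beyond the scatter) and an at least 11-fold higher number from compound 1 to compound 3 (1.05 log units; beyond the scatter). Both new steps rest on a limit, not a number, for compound 3 in this assay: the limit of > 100000 nM in this assay, at which 1 of the 3 values shown sits.

The exchange changes both the link to the core, from nitrogen to oxygen, and the chain, which now contains a ring, so the two effects remain unseparated. A 3-hydroxypropoxy group or a (pyrrolidin-2-yl)methylamino group at this carbon would tell them apart.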